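The source may hold more compounds than are shown below. What is called first, only, known or untested is meant among the compounds shown, and "the series" means these compounds.

Measured compounds in a functional assay on the whole organism with Rattus norvegicus as the target, with a stated time of 4 h, at a dose of 40 mg/kg by the intraperitoneal route; on this read-out lower numbers stand for less inhibition and higher numbers for more inhibition at the one dose given (going by the name of the read-out):
Compound 1, `Cc1cn2cccc(OCc3ccccc3)c2n1`: 62%
Compound 2, `Cc1nc2c(OCc3ccccc3)cccn2c1C#N`: 25%

Among the two numbers, compound 2 stands lowest; its nearest neighbour is compound 1, the difference being a number 37 percentage points lower from compound 1 to compound 2 (beyond the scatter). Compound 3, `COCc1c(C)nc2c(OCc3ccccc3)cccn12`, differs from compound 2 by one change: methoxymethyl in place of cyano on an aromatic carbon. Among the measured compounds shown here, only one measured step bears on this change, and only indirectly: in it a cyano took the place of hydrogen on this same aromatic carbon and the read-out fell by a number 37 percentage points lower from compound 1 to compound 2 (beyond the scatter). Here the cyano leaves again, but what enters is a methoxymethyl rather than hydrogen, and no measured pair shows a methoxymethyl at this place. The expectation is therefore a rise from compound 2 toward the number of compound 1, without a firm basis for its full size. Compound 3 is estimated to give 45% in this assay, within 20% to 70%, which means an expected step of a number 20 percentage points higher from compound 2 to compound 3 (beyond the scatter).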

Compound 3, a percentage reported as inhibition, in the whole organism at one dose (the size of the read-out at that dose, not a potency): 99%
The estimate for compound 3 lay 54 percentage points below the measured number; the whole stated range lies below it.
By their numbers in this assay, from the lowest: compound 2; then compound 1; then compound 3.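

In this assay, the aromatic carbon that carries the cyano in compound 2 turns out to allow a rise as well as a fall: methoxymethyl in place of cyano gives a large step (a number 74 percentage points higher from compound 2 to compound 3 (beyond the scatter)), and methoxymethyl in place of hydrogen also gives a large step (a number 37 percentage points higher from compound 1 to compound 3 (beyond the scatter)). The earlier pair had shown only a fall at this carbon, so the hydrogen of compound 1 does not mark the top of the range here, and a group on this carbon does not in itself lower the read-out. Nothing measured here explains why cyano and methoxymethyl part so widely.

From the compounds shown here alone, it stays open whether the oxygen of methoxymethyl matters or the chain alone does, a question that a hydroxymethyl, an ethyl or a longer ether chain at this carbon would address. Going by these compounds, how an amine or a carboxylic acid would fare at this carbon also remains unknown.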